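This account rests on a few compounds, and the source may have more. Where it says the series, first, only, none or still open, it means among the compounds named here.

Measured in a functional assay on HeLa cells (Homo sapiens) for antiproliferative activity, read by MTT assay, with a stated time of 48 h; a higher number here means a weaker inhibitor, a lower number a stronger inhibitor:
- compound 1 `Fc1ccc(-c2nn(-c3ccccc3)cc2-c2nc3cc(Cl)ccc3[nH]2)cc1`: 2770 nM
- compound 2 `Fc1ccc(-c2nn(-c3ccccc3)cc2-c2nc3cc(Br)ccc3[nH]2)cc1`: 4940 nM
- compound 3 `Fc1ccc(-c2nn(-c3ccccc3)cc2-c2nc3cc(Cl)c(Cl)cc3[nH]2)cc1`: 11600 nM

Of the three, compound 3 has the highest number, 11600 nM, and lies beyond the scatter from both others. Still unmeasured is compound 4 `Clc1ccc(-c2nn(-c3ccccc3)cc2-c2nc3cc(Cl)c(Cl)cc3[nH]2)cc1`, which differs from compound 3 at one place: chloro in place of fluoro on an aromatic carbon. This is chloro in place of fluoro on an aromatic carbon, 4-fluorophenyl to 4-chlorophenyl.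

Among the compounds with values here, no measured step covers this place. Within the data shown here, the closest precedent is a swap of one halogen for another at a different place, a 1.8-fold higher number from compound 1 to compound 2 (0.25 log units; within the scatter), which stays within the scatter. The other step, a 4.2-fold higher number from compound 1 to compound 3 (0.62 log units; beyond the scatter), is modest, but it adds a halogen rather than swapping one, so it bears less directly. Going by these compounds, on this thin evidence, no change beyond the scatter is expected in this assay, and the direction remains open. The expected change is a 1.0-fold higher number from compound 3 to compound 4 (0.01 log units; within the scatter). For compound 4 the estimated value is 12000 nM, with an expected range of 5000 nM to 28000 nM.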

Compound 4, half-maximal inhibitory concentration: 12100 nM
For compound 4 the middle estimate is 1.0-fold (0.00 log units) below the measured one, within the range that was stated.
By their numbers in this assay, from the lowest: compounds 1 and 2 (each within the scatter of the next); then compounds 3 and 4 (each within the scatter of the next).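

In this assay, the change from 4-fluorophenyl to 4-chlorophenyl gives a 1.0-fold higher number from compound 3 to compound 4 (0.02 log units; within the scatter). Within the data shown here, this is the first reading at this place, on an aromatic carbon para to a large group, as the earlier steps changed only the halogens elsewhere on the core. With the rest of compound 3 held fixed, fluoro and chloro are thus interchangeable here in this assay, although that rests on a single pair and no information is available on why the two read alike.

Still open, going by these compounds, is whether this place accepts anything other than a halogen, such as an amine, a methoxy group or a carboxylic acid. Among these compounds, it is also open whether the same swap would read alike with the single chloro of compound 1 in place of the two chloro groups of compound 3.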